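A few compounds are considered here, and "the series" means these few. Any claim that something is new, unique, unknown or untested is made for them only; others in the source may bear on it.

Measured so far:
Compound 1, `Cc1nc2ccccc2c(=O)n1NC(=O)NC1CCCCC1`: 41.9%
Compound 2, `Cc1nc2ccccc2c(=O)n1NS(=O)(=O)c1ccccc1`: 22.2%
Compound 3, `Cc1ccc(S(=O)(=O)Nn2c(C)nc3ccccc3c2=O)cc1`: 24.2%

In a functional assay on the whole organism (strain Sprague-Dawley) for inhibition, with Rattus norvegicus as the target, read by paw edema, with stated times of 30 min and 2 h, at a dose of 80 mg/kg by the oral route (on this read-out higher numbers stand for more inhibition at the one dose given (going by the name of the read-out) and lower numbers for less inhibition), compound 1 stands highest of the three; compound 3 lies nearest and compound 2 furthest, both beyond the scatter. Going by the values given here, the only measured step, a number 2 percentage points higher from compound 2 to compound 3 (within the scatter), is within the scatter. Compound 4, `O=C(NC1CCCCC1)Nn1c(CO[N+](=O)[O-])nc2ccccc2c1=O`, differs from compound 1 by nitrooxy in place of hydrogen on a saturated chain carbon bound to an aromatic carbon. Among the compounds with values here, no measured step concerns this kind of change: the one step measured swaps methyl for hydrogen on an aromatic carbon within the sulfonyl pair and does not bear on a nitrooxy entering on a saturated chain carbon. With nothing beyond the value of compound 1 to go on, no step beyond the scatter is expected, so the estimated step of a number 2.1 percentage points higher from compound 1 to compound 4 (within the scatter) stays small. Compound 4 is estimated at 44%, with a range from 24% to 64%.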

Compound 4, a percentage reported as inhibition, in the whole organism at one dose (the size of the read-out at that dose, not a potency): 18.7%
The estimate for compound 4 lay 25.3 percentage points above the measured number; measured number below the stated range.
By their numbers in this assay, from the lowest: compounds 4, 2 and 3 (each within the scatter of the next); then compound 1.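

In this assay, methyl to (nitrooxy)methyl on the saturated chain carbon bound to an aromatic carbon gives a number 23.2 percentage points lower from compound 1 to compound 4 (beyond the scatter), so this position does respond to substitution, and nitrooxy here lowers the read-out. Going by these compounds alone, the only earlier step, on an aromatic carbon within the sulfonyl pair, stayed within the scatter, which makes this the first single change that moves the number beyond it. Nothing available bears on the reason for this drop.

On these data alone, whether the drop belongs to nitrooxy itself or to any larger group on this carbon remains open, as does the reading of a hydroxyl, an amine or a carboxylic acid in the same place. Also open, as far as these compounds go, is whether nitrooxy at this carbon acts the same way in the sulfonyl compounds.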